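Side-chain change from ethoxymethyl to acetyl: working notes

The source may report more compounds than this note shows. Statements on the series, on what has been measured and on what is new or still open speak of the compounds shown alone.

Measured in a functional assay (trachea) with Cavia porcellus as the target; on this read-out lower numbers stand for an effect already at smaller amounts and higher numbers for an effect only at larger amounts of compound:
- compound 1 `CCCn1c(=O)n(CCN(C)C)c(=O)c2[nH]cnc21`: 2700 nM
- compound 2 `CCCn1c(=O)n(CCOCC)c(=O)c2[nH]cnc21`: 70 nM

Of the two measured compounds, compound 2 has the lower number in this assay, at 70 nM, while compound 1 gives 2700 nM.

The next compound is compound 3 `CCCn1c(=O)n(CC(C)=O)c(=O)c2[nH]cnc21`, with the shared core kept and one change to the side chain: acetyl in place of ethoxymethyl on a saturated chain carbon bound to an aromatic nitrogen. In words, acetyl takes the place of ethoxymethyl on a saturated chain carbon bound to an aromatic nitrogen.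

Going by the values given here, only one measured step bears on this change: a 39-fold lower number from compound 1 to compound 2 (1.59 log units; beyond the scatter). It was large, and it exchanged dimethylamino for ethoxy on the same side chain. Compound 3 carries no dimethylamino group, so that step sets no size for this change and serves only as a loose upper guide. Among the compounds with values here, no measured pair exchanges ethoxymethyl for acetyl.

A modest move towards a higher number is therefore expected, much smaller than the step to compound 2 and possibly not beyond the scatter. The expected step is a 2.9-fold higher number from compound 2 to compound 3 (0.46 log units; beyond the scatter). For compound 3 the estimated value is 200 nM, with an expected range of 50 nM to 800 nM.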

Compound 3, half-maximal effective concentration: 14900 nM
Beside the measured number, compound 3's estimate is 75-fold (1.87 log units) below it; measured number above the stated range.
By their numbers in this assay, from the lowest: compound 2; then compound 1; then compound 3.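

In this assay, the exchange of ethoxymethyl for acetyl gives a 210-fold higher number from compound 2 to compound 3 (2.33 log units; beyond the scatter) even though the HOW-level counts barely move: both groups carry no net charge, no ring, no hydrogen-bond donor and one hydrogen-bond acceptor, so these counts do not track the read-out at this position on a saturated chain carbon bound to an aromatic nitrogen. Compound 3 also carries no dimethylamino group, yet the change from the amine side chain gives a 5.5-fold higher number from compound 1 to compound 3 (0.74 log units; beyond the scatter), so across these three compounds the loss of dimethylamino does not by itself bring a lower number, and the low value belongs to the ethoxymethyl side chain of compound 2 rather than to any side chain without the amine. Nothing on hand gives a reason for the size of these steps.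

The change to acetyl alters chain length and brings in a carbonyl at once, so the compounds shown do not separate the two, and a propanoyl group would bear on that. As far as these compounds go, it also remains open whether the ether oxygen of compound 2 matters at all, which a plain butyl chain in the same place would address.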